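This account rests on a few compounds, and the source may have more. Where it says the series, first, only, none or still open, it means among the compounds named here.

The measured compounds:
Compound 1 `COc1ccc(-n2nncc2CN2C(=O)C3(C(C#N)=C(N)Oc4c3c3nc5ccccc5nc3c3ccccc43)c3ccccc32)cc1` gives > 50000 nM in a functional assay on HCT-116 cells (Homo sapiens) for antiproliferative activity, read by MTT assay, with a stated time of 48 h (on this read-out lower numbers stand for stronger inhibition and higher numbers for weaker inhibition), which is a limit of the assay and not a number.
Compound 2 `CCOc1ccccc1-n1nncc1CN1C(=O)C2(C(C#N)=C(N)Oc3c2c2nc4ccccc4nc2c2ccccc32)c2ccccc21` gives > 50000 nM, again a limit.
Compound 3 `Cc1ccc(Cl)cc1-n1nncc1CN1C(=O)C2(C(C#N)=C(N)Oc3c2c2nc4ccccc4nc2c2ccccc32)c2ccccc21` gives > 50000 nM, again a limit.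

Compound 1 therefore stands only at a limit of this assay, with no number of its own to place it against the others. The three steps among the measured compounds, a step that the two limits leave unreadable from compound 1 to compound 2, a step that the two limits leave unreadable from compound 1 to compound 3 and a step that the two limits leave unreadable from compound 2 to compound 3, are all unreadable in size, since each of them runs from one limit to another; all that is shown is the limit of > 50000 nM in this assay, at which 3 of the 3 values shown sit.

The change from compound 1 to compound 4 `N#CC1=C(N)Oc2c(c3nc4ccccc4nc3c3ccccc23)C12C(=O)N(Cc1cnnn1-c1cc(Cl)ccc1Cl)c1ccccc12` is this: 2,5-dichlorophenyl in place of 4-methoxyphenyl on an aromatic nitrogen. The measured steps that bear on it are the three exchanges of the aryl group on the same aromatic nitrogen, and none of them moved any compound off the limit. No step shown gives a reason to expect compound 4 to behave differently, so the step that the limit leaves unreadable from compound 1 to compound 4 is expected to be none beyond the scatter, with compound 4 most likely again reported only as a limit. The estimate for compound 4 in this assay is 80000 nM, in a range from 30000 nM to 300000 nM.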

Compound 4, half-maximal inhibitory concentration: > 50000 nM
Compound 4: only a limit was reported; the forecaster's own chance of this, stated with the estimate: 85%; the middle value lies beyond the limit too.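

Compound 4 stands only at a limit in this assay, as do compounds 1, 2 and 3, so none of the steps from compounds 1, 2 and 3 to compound 4 can be read: the limit of > 50000 nM in this assay, at which 4 of the 4 values shown sit.

The compounds shown leave open whether any aryl group on this aromatic nitrogen would give a readable value in this assay.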